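Aromatic substituent changes, compounds 1 to 4

A few compounds are considered here, and "the series" means these few. Any claim that something is new, unique, unknown or untested is made for them only; others in the source may bear on it.

Measured so far in a functional assay on MDA-MB-231 cells (Homo sapiens) for inhibition; on this read-out higher numbers stand for weaker inhibition and lower numbers for stronger inhibition:
- compound 1 `CC(C)c1ccc(N2C(=O)C=CC2OCC(F)(F)F)cc1`: compound 1 gives 6640 nM
- compound 2 `Cc1ccc(N2C(=O)C=CC2OCC(F)(F)F)cc1`: compound 2 gives 15800 nM
- compound 3 `O=C1C=CC(OCC(F)(F)F)N1c1ccc([N+](=O)[O-])cc1`: compound 3 gives 2830 nM
- compound 4 `COC(=O)c1ccc(N2C(=O)C=CC2OCC(F)(F)F)cc1`: not yet measured

Compound 3 holds the lowest number of the three, with a 2.3-fold lower number from compound 1 to compound 3 (0.37 log units; beyond the scatter) and a 5.6-fold lower number from compound 2 to compound 3 (0.75 log units; beyond the scatter) both beyond the scatter. The next step is methoxycarbonyl in place of nitro on an aromatic carbon. For the measured compounds named here, no measured step involves the methoxycarbonyl group, so the relevant comparisons are the three exchanges at this same position: a 2.4-fold higher number from compound 1 to compound 2 (0.38 log units; beyond the scatter), a 2.3-fold lower number from compound 1 to compound 3 (0.37 log units; beyond the scatter) and a 5.6-fold lower number from compound 2 to compound 3 (0.75 log units; beyond the scatter), all modest. A modest step in this assay is therefore expected for compound 4, most plausibly towards a somewhat higher number than compound 3, with the direction uncertain. Compound 4 is estimated at 4500 nM, expected between 1500 nM and 13000 nM, meaning a 1.6-fold higher number from compound 3 to compound 4 (0.20 log units; within the scatter).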

Compound 4, half-maximal inhibitory concentration: 12100 nM
Estimate against measurement, compound 4: 2.7-fold (0.43 log units) below, and the stated range covers the measured number.
By their numbers in this assay, from the lowest: compound 3; then compounds 1, 4 and 2 (each within the scatter of the next, the first and the last beyond it).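

In this assay, methoxycarbonyl does not reproduce the result of nitro, although both groups have the same counts of hydrogen-bond acceptors and double bonds: a 4.3-fold higher number from compound 3 to compound 4 (0.63 log units; beyond the scatter). Compound 4 stays within the scatter of both alkyl-substituted compounds, with a 1.3-fold lower number from compound 2 to compound 4 (0.12 log units; within the scatter) and a 1.8-fold higher number from compound 1 to compound 4 (0.26 log units; within the scatter), leaving compound 3 as the strongest inhibitor of the four. No available evidence explains the gap between the nitro and methoxycarbonyl groups. Going by these compounds, whether the stronger inhibition is particular to nitro stays open: a nitrile, a trifluoromethyl group, a carboxylic acid or an amine at this position could test it.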